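The source may report more compounds than this note shows. Statements on the series, on what has been measured and on what is new or still open speak of the compounds shown alone.

Working notes on the series.

Compound 1 `O=C(O)CCC1Cc2ccc(-c3cc(F)cc(OC(F)F)c3)cc2N1S(=O)(=O)c1cccc(C(F)(F)F)c1` and compound 2 `O=C(O)CCCC1Cc2ccc(-c3cc(F)cc(OC(F)F)c3)cc2N1S(=O)(=O)c1cccc(C(F)(F)F)c1` share one core and differ only in the acid chain. In an ADME assay on microsomes from liver (Mus musculus) for metabolic stability, read by LC-MS, using NADPH, with a stated time of 60 min, tested at 1 uM (a higher number here means that the compound lasts longer, a lower number that the compound disappears faster), compound 1 gives 1.02 h, and in this assay compound 2 gives 1.56 h. The change between them is carboxymethyl in place of carboxy on a saturated chain carbon, two bonds along the chain from a saturated ring carbon; the step it made reads a 1.5-fold higher number from compound 1 to compound 2 (0.18 log units; within the scatter), so the two values are not told apart by this measurement.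

Compound 3 `O=C(O)CCC1CN(S(=O)(=O)c2cccc(C(F)(F)F)c2)c2cc(-c3cc(F)cc(OC(F)F)c3)ccc21` carries the same atoms as compound 1 joined differently; the difference between the two cores is not broken down here. In this assay compound 3 gives 0.408 h, the lowest of the three numbers: compound 1 sits a clear distance above it, and compound 2 further still, both beyond the scatter.

Compound 4 `O=C(O)CCCC1CN(S(=O)(=O)c2cccc(C(F)(F)F)c2)c2cc(-c3cc(F)cc(OC(F)F)c3)ccc21` is the counterpart of compound 3 on this second core. The change from compound 3 to compound 4 is carboxymethyl in place of carboxy on a saturated chain carbon, two bonds along the chain from a saturated ring carbon, the same change already made from compound 1 to compound 2 on the first core. Going by the values given here, the one precedent is a small step, within the scatter, so the expectation for compound 4 is a step of about the same size from compound 3, estimated as a 1.5-fold higher number from compound 3 to compound 4 (0.17 log units; within the scatter), resting on a 1.5-fold higher number from compound 1 to compound 2 (0.18 log units; within the scatter) and on compound 3 at 0.408 h. On that basis compound 4 is expected to give about 0.6 h in this assay, likely between 0.3 h and 1.2 h, pending the measurement.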

Compound 4, half-life: 0.57 h
Beside the measured number, compound 4's estimate is 1.1-fold (0.02 log units) above it; low and high end bracket the measured number.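

In this assay, the new step reads a 1.4-fold higher number from compound 3 to compound 4 (0.15 log units; within the scatter), so this measurement does not tell the two compounds apart. Set beside the earlier step, carboxymethyl in place of carboxy behaves alike on the two cores, and the two steps themselves cannot be told apart: the same change on two cores in this assay, a 1.5-fold higher number (0.18 log units; within the scatter) from compound 1 to compound 2 and a 1.4-fold higher number (0.15 log units; within the scatter) from compound 3 to compound 4, 1.1-fold (0.04 log units) apart, within the scatter of two such steps. This shows that, within this pair of matched compounds, the change from 2-carboxyethyl to 3-carboxypropyl gives a step of similar, small size on both cores; it does not show that the change has any real effect on half-life, since neither step rises above the scatter, and agreement between two small steps is weak support for transfer to any further core.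

The compounds shown leave open how the read-out responds to a chain longer than 3-carboxypropyl or to a chain shorter than 2-carboxyethyl, and whether a larger step would carry over from one core to the other in the same way. They also leave open what an amide or a tetrazole would do in place of the carboxylic acid on either core.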